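Swapping the aryl group on the piperazine nitrogen

The compounds below may be only part of what the source reports. "The series", "measured", "known", "first", "only" and "open" are said of these compounds alone.

Compound 1 `COc1ccc(N2CCN(Cc3csc(N)c3C(=O)c3ccc(Cl)cc3)CC2)cc1` was tested in an assay on CHO cells for displacement of a labelled ligand from adenosine receptor A3 (Homo sapiens), read by scintillation counting, with a stated time of 120 min, tested at 10 uM (on this read-out higher numbers stand for more inhibition at the one concentration tested (going by the name of the read-out) and lower numbers for less inhibition), and gave 0%. Compound 2 `Nc1scc(CN2CCN(c3ccccc3F)CC2)c1C(=O)c1ccc(Cl)cc1` gave 0%, and compound 3 `Nc1scc(CN2CCN(c3ccc(F)c(F)c3)CC2)c1C(=O)c1ccc(Cl)cc1` gave 1%. Compound 1 therefore stands level with compound 2 at the digits shown, and the two together are the lowest of the three numbers; the nearest neighbour is compound 2, the furthest is compound 3, and all three lie within the scatter of one another.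

The new compound 4 `Nc1scc(CN2CCN(c3ccccc3Cl)CC2)c1C(=O)c1ccc(Cl)cc1` differs from compound 1 as follows: 2-chlorophenyl in place of 4-methoxyphenyl on an amine nitrogen in a ring.

Among the measured compounds shown here, three measured steps bear on this change. Each of them also swaps the aryl group on the same ring nitrogen. From compound 1 to compound 2 the step was no change at the digits printed from compound 1 to compound 2 (within the scatter). From compound 1 to compound 3 it was a number 1 percentage points higher from compound 1 to compound 3 (within the scatter), and from compound 2 to compound 3 it was a number 1 percentage points higher from compound 2 to compound 3 (within the scatter). None of these moved the read-out beyond the scatter, whichever halogenated phenyl group entered.

On this basis compound 4 is expected to show no step beyond the scatter, with a number 1 percentage points higher from compound 1 to compound 4 (within the scatter) as the estimated change. Compound 4 is thus estimated at 1%, with a range from -8% to 10%.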

Compound 4, a percentage reported as inhibition, at one concentration (the size of the read-out at that concentration, not a potency): 0%
Beside the measured number, compound 4's estimate is 1 percentage points above it; low and high end bracket the measured number.
By their numbers in this assay, from the lowest: compounds 1, 2, 4 and 3 (each within the scatter of the next).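

In this assay, among the compounds shown here, the direct halogen swap, chloro in place of fluoro on an aromatic carbon, gives no change at the digits printed from compound 2 to compound 4 (within the scatter) and so shows what no earlier pair could: exchanging the halogen itself leaves the number where it was. The 2-chlorophenyl group also stands level with the other aryl groups, with no change at the digits printed from compound 1 to compound 4 (within the scatter) and a number 1 percentage points lower from compound 3 to compound 4 (within the scatter) as its steps, so the flat picture on this ring nitrogen now takes in chlorine as well as fluorine and methoxy. No measurement available here explains why these numbers sit so close together.

All four compounds lie at the very bottom of the scale, so this series cannot tell whether the aryl groups truly make no difference or whether any difference is simply hidden at the one concentration tested. Going by these compounds, whether something quite different on this nitrogen, such as a carboxylic acid on a longer chain or a simple acetyl group in place of the aryl ring, would lift the number clear of the scatter remains open.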